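From pyridin-2-yl to phenyl at the assay limit

This account rests on a few compounds, and the source may have more. Where it says the series, first, only, none or still open, it means among the compounds named here.

compound 1 (`O=C(Nc1ncc(Cc2ccccn2)s1)C1CCCCC1`) gives > 40000 nM (a limit)
compound 2 (`O=C(CCC1CCCCC1)Nc1ncc(Cc2ccccc2)s1`) gives > 40000 nM (a limit)
compound 3 (`O=C(CCC1CCCCC1)Nc1ncc(Cc2ccccn2)s1`) gives > 40000 nM (a limit)

These compounds were tested in an ADME assay on P388D1 cells (Mus musculus) for cytotoxicity, read by fluorescence and resazurin assay, with a stated time of 72 h; a higher number here means a weaker inhibitor, a lower number a stronger inhibitor. In this assay compound 1 gives > 40000 nM, which is a limit and not a number. Among the measured compounds shown here, it therefore has no exact place among the others, since all of the values so far share that one limit: the limit of > 40000 nM in this assay, at which 3 of the 3 values shown sit.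

Compound 4 (`O=C(Nc1ncc(Cc2ccccc2)s1)C1CCCCC1`) has not yet been measured. Its difference from compound 1 is this: phenyl in place of pyridin-2-yl on a saturated chain carbon bound to an aromatic carbon.

For the measured compounds named here, only one measured step bears on this change, and it runs the opposite way: a step that the two limits leave unreadable from compound 2 to compound 3. Its size cannot be read, so it offers no measured size or direction. Compound 2, which also carries phenyl at this place, gives > 40000 nM, again a limit.

No step beyond the usual scatter is expected, and the estimated step is a number no higher from compound 1 to compound 4 (the limit leaves the size open). For compound 4 the expected value is 40000 nM, with an estimated range from 20000 nM to 80000 nM.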

Compound 4, half-maximal inhibitory concentration: > 40000 nM
Compound 4: only a limit was reported; the forecaster's own chance of this, stated with the estimate: 80%; the middle value lies on the limit itself.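

In this assay, among the compounds shown here, compound 4 gives > 40000 nM as a limit and not a number, so no step from compound 1 to compound 4 can be read: the limit of > 40000 nM in this assay, at which 4 of the 4 values shown sit. Whether phenyl and pyridin-2-yl differ at all here, and at what concentration any of the compounds shown would affect these cells, stays open.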